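Selenium in place of oxygen at the salicyloyl carbonyl

The source may hold more compounds than are shown below. What is called first, only, known or untested is meant among the compounds shown, and "the series" means these compounds.

Measured compounds:
compound 1, `CC(=O)Oc1ccccc1C(=O)NCC[Se]C#N`, 2100 nM
compound 2, `CC(=O)Oc1ccccc1C(=O)OCC[Se]C#N`, 20200 nM
compound 3, `CC(=O)Oc1ccccc1C(=O)[Se]CC[Se]C(=O)c1ccccc1OC(C)=O`, 5500 nM

In a functional assay on HT-29 cells (Homo sapiens) for antiproliferative activity, read by MTT assay, with a stated time of 72 h (on this read-out lower numbers stand for stronger inhibition and higher numbers for weaker inhibition), compound 2 gives the highest of the three numbers, 20200 nM. Compound 3 gives 5500 nM, and compound 1 gives 2100 nM. Compound 4, `CC(=O)Oc1ccccc1C(=O)[Se]CC[Se]C#N`, differs from compound 2 by a group of 6 heavy atoms (3 carbon, 1 nitrogen, 2 selenium; no ring) in place of a group of 6 heavy atoms (3 carbon, 1 nitrogen, 1 oxygen, 1 selenium; no ring), on a carbonyl carbon.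

Among the measured compounds shown here, one measured step touches the same carbonyl carbon: a 9.6-fold higher number from compound 1 to compound 2 (0.98 log units; beyond the scatter), where an oxygen-linked chain replaced a nitrogen-linked one and the number rose. Compound 3, which carries a selenium-linked chain on that carbonyl at both ends of its core, shows a lower number than compound 2 without a step being drawn between them. Both observations point the same way: exchanging the oxygen at the carbonyl for another atom has gone with lower numbers. A modest step downward in this assay is therefore expected from compound 2 to compound 4, a 4.0-fold lower number from compound 2 to compound 4 (0.61 log units; beyond the scatter). Compound 4 is estimated at 5000 nM, with a range from 1500 nM to 15000 nM.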

Compound 4, half-maximal inhibitory concentration: 17700 nM
Compound 4: the middle estimate sits 3.5-fold (0.55 log units) below what was measured, outside the stated range (above it).
By their numbers in this assay, from the lowest: compound 1; then compound 3; then compounds 4 and 2 (each within the scatter of the next).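

In this assay, selenium in place of oxygen on this carbonyl carbon, whose other neighbour is an aromatic carbon, makes no difference beyond the scatter, with a 1.1-fold lower number from compound 2 to compound 4 (0.06 log units; within the scatter). The nitrogen-linked chain of compound 1 stands apart, with an 8.4-fold higher number from compound 1 to compound 4 (0.93 log units; beyond the scatter), a step of about the same size as a 9.6-fold higher number from compound 1 to compound 2 (0.98 log units; beyond the scatter). Among these three single-atom variants, then, the oxygen-linked and selenium-linked chains give numbers within the scatter of each other, and only the nitrogen-linked chain differs from them beyond it.

Going by these compounds, whether a sulfur atom at the carbonyl, or a longer chain on it, would give a number like that of compound 1 or like those of compound 2 and compound 4 stays open. The data at hand offer no measurement that accounts for the separation of compound 1 from the other two.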